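Fluoro to bromo on the way to compound 4

The source may report more compounds than this note shows. Statements on the series, on what has been measured and on what is new or still open speak of the compounds shown alone.

In a functional assay on K562 cells (Homo sapiens) for cytotoxicity, read by MTT assay, with a stated time of 24 h (on this read-out lower numbers stand for stronger inhibition and higher numbers for weaker inhibition), compound 3 `CN1C/C(=C\c2ccc(F)cc2)C(=O)/C(=C/c2cccc([N+](=O)[O-])c2)C1` gives 11300 nM. This number lies within the scatter of compound 2 `COc1cc(/C=C2\CN(C)C/C(=C\c3ccc(Br)cc3)C2=O)cc(OC)c1OC` at 12400 nM. Compound 1 `COc1cc(/C=C2\CN(C)C/C(=C\c3cccc([N+](=O)[O-])c3)C2=O)cc(OC)c1` reads lower at 4420 nM, a gap beyond the scatter from compound 3, which therefore sits in the upper pair of the three numbers.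

Compound 4 `CN1C/C(=C\c2ccc(Br)cc2)C(=O)/C(=C/c2cccc([N+](=O)[O-])c2)C1` differs from compound 3 in one place, with bromo in place of fluoro on an aromatic carbon. Among the compounds with values here, no measured pair isolates this change, so the evidence is indirect. Compound 2 carries a 4-bromophenyl group, although the rest of its structure differs, and gives 12400 nM, within the scatter of compound 3 with its 4-fluorophenyl group. In this assay, no step beyond the scatter is therefore expected, with at most a slight drift toward a lower number. The expected change is a 1.3-fold lower number from compound 3 to compound 4 (0.10 log units; within the scatter). The estimate for compound 4 is 9000 nM, with an expected range of 4500 nM to 18000 nM.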

Compound 4, half-maximal inhibitory concentration: > 20000 nM
Compound 4 gave a limit, no number (the forecaster's own chance of this, stated with the estimate: 3%); middle value at least 2.2-fold (0.34 log units) from the limit.
By their numbers in this assay, from the lowest: compound 1; then compounds 3 and 2 (each within the scatter of the next). At a limit, above all of these: compound 4.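

In this assay compound 4 gives > 20000 nM, which is a limit of the assay and not a number. This is the only pair shown that isolates the change from 4-fluorophenyl to 4-bromophenyl on an otherwise unchanged structure, and it reads an at least 1.7-fold higher number from compound 3 to compound 4 (0.24 log units; that floor lies within the scatter), so bromo at this position brings no gain in this assay, although the true size of the step remains unknown. Among the values shown, this is the only reading that is not a number: the limit of > 20000 nM in this assay, at which 1 of the 4 values shown sits.

From the compounds shown here alone, whether the real step lies beyond the scatter remains open, as compound 4 has only a limit. Also open, going by these compounds, is how the same position reads with chloro, an amine or a carboxylic acid in place of the halogens here, and whether the outcome of this change holds on the other compounds' substitution patterns.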